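Aryl sulfonate series: para substituent on the benzoyl ring

The source may report more compounds than this note shows. Statements on the series, on what has been measured and on what is new or still open speak of the compounds shown alone.

Measured compounds:
compound 1 `COc1ccc(C(=O)N2CCC(n3cncc3-c3ccc(OS(=O)(=O)c4cccc5cnccc45)cc3)CC2)cc1` gives 77 nM
compound 2 `CNC(=O)c1cccc(S(=O)(=O)Oc2ccc(-c3cncn3C3CCN(C(=O)c4ccc(N(C)C)cc4)CC3)cc2)c1` gives 25 nM

Both values come from an assay on HEK293 cells for antagonist activity at P2X purinoceptor 7 (Homo sapiens), read by fluorescence, with a stated time of 2 h; a higher number here means a weaker inhibitor, a lower number a stronger inhibitor. Of the two measured compounds, compound 2 stands with the lowest number; the nearest is compound 1, whose value lies beyond the scatter above it. Among the measured compounds shown here, the two compounds differ in more than one place, so no single step between them is available, and only their two values can be compared.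

Compound 3 `CNC(=O)c1cccc(S(=O)(=O)Oc2ccc(-c3cncn3C3CCN(C(=O)c4ccc(OC)cc4)CC3)cc2)c1` is not yet measured. It is derived from compound 2 by a single change: methoxy in place of dimethylamino on an aromatic carbon. Compound 1 also carries the methoxy group on that ring, but with a different aryl sulfonate, so it does not show this step on its own.

For the measured compounds named here, with no measured step for this change, the expectation for compound 3 in this assay rests on the values of compound 2 and compound 1 only. A step of a 1.8-fold higher number from compound 2 to compound 3 (0.26 log units; within the scatter) is expected, close to or slightly beyond the scatter, toward a weaker inhibitor. Compound 3 is estimated at 45 nM, with a range from 15 nM to 130 nM.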

Compound 3, half-maximal inhibitory concentration: 159 nM
For compound 3 the middle estimate is 3.5-fold (0.55 log units) below the measured one; the whole stated range lies below it.
By their numbers in this assay, from the lowest: compound 2; then compound 1; then compound 3.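

In this assay, the change from 4-(dimethylamino)phenyl to 4-methoxyphenyl on the carbonyl now has a measured size, a 6.4-fold higher number from compound 2 to compound 3 (0.80 log units; beyond the scatter), so the group on this aromatic carbon, para to a large group, clearly affects the number with the rest of the structure held constant. Compound 3 also links compound 1 and compound 2 by one change each: with methoxy held in place, 3-(methylcarbamoyl)phenyl in place of isoquinolin-5-yl on the sulfonyl sulfur gives a 2.1-fold higher number from compound 1 to compound 3 (0.31 log units; beyond the scatter), showing that the group on the sulfonyl sulfur matters as well. The data give no measured basis for explaining either step.

The compounds shown leave open whether the step belongs to dimethylamino in particular, since a primary amine, a methylamino group, a pyrrolidine ring or an ethoxy group at this carbon would separate the effect of the nitrogen from that of its methyl groups. They also leave open whether the dimethylamino to methoxy step keeps its size when isoquinolin-5-yl sits on the sulfonyl sulfur, which would need the dimethylamino partner of compound 1.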